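Hydrogen for methyl on the triazole nitrogen

This account rests on a few compounds, and the source may have more. Where it says the series, first, only, none or still open, it means among the compounds named here.

Measured so far:
compound 1 `Cn1c(Sc2ccc(C(=O)NO)cc2)nnc1-c1cccs1` gives 8 nM
compound 2 `O=C(NO)c1ccc(Cc2nnc[nH]2)cc1` gives 198 nM
compound 3 `Cn1c(Cc2ccc(C(=O)NO)cc2)nnc1-c1ccccc1` gives 17 nM

These three compounds were tested in an assay on Sf9 cells for inhibition of protein deacetylase HDAC6 (Homo sapiens), read by fluorescence; a lower number here means a stronger inhibitor, a higher number a weaker inhibitor. Among them, compound 3 stands second highest of the three numbers. Its nearest neighbour is compound 1, which lies below it, a gap beyond the scatter; its furthest is compound 2, which lies well above it, also beyond the scatter. No pair of these compounds differs in a single place, so no single-point step has been measured.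

Compound 4 `O=C(NO)c1ccc(Cc2nnc(-c3ccccc3)[nH]2)cc1` is not yet measured. It differs from compound 3 by hydrogen in place of methyl on an aromatic nitrogen of a five-membered aromatic ring with 3 nitrogen, the phenyl group kept. Among the measured compounds shown here, the only measured compound with hydrogen on that nitrogen is compound 2, and it also lacks the phenyl group, so its value cannot be read as the effect of this change alone. A modest loss is expected in this assay, because compound 2 with hydrogen on that nitrogen gives 198 nM while every methyl-bearing compound gives a lower number. The expected step of a 2.4-fold higher number from compound 3 to compound 4 (0.37 log units; beyond the scatter) is therefore upward, of moderate size. Compound 4 is expected to give 40 nM, with a range from 12 nM to 130 nM.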

Compound 4, half-maximal inhibitory concentration: 5 nM
The estimate for compound 4 lay 8.0-fold (0.90 log units) above the measured number; measured number below the stated range.
By their numbers in this assay, from the lowest: compounds 4 and 1 (each within the scatter of the next); then compound 3; then compound 2.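

In this assay, the methyl on the aromatic nitrogen is not needed for a low number when the phenyl group is kept: hydrogen in its place gives a 3.4-fold lower number from compound 3 to compound 4 (0.53 log units; beyond the scatter). Phenyl in place of hydrogen on the aromatic carbon gives a 40-fold lower number from compound 2 to compound 4 (1.60 log units; beyond the scatter), so the high number of compound 2 goes with the missing phenyl group, not with the hydrogen on the nitrogen. Nothing available accounts for either step.

The compounds shown leave open how an ethyl group or a longer chain on that nitrogen would compare with hydrogen and methyl. They also leave open whether hydrogen in place of methyl gives a step of the same direction on the core of compound 1, and whether an amine or a carboxylic acid on the phenyl group would be tolerated.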